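The compounds below may be only part of what the source reports. "The series", "measured", "known", "first", "only" and "open" are said of these compounds alone.

Among the compounds with values here, in a physicochemical assay for solubility, measured as kinetic solubility, at pH 6.5 (on this read-out lower numbers stand for lower solubility and higher numbers for higher solubility), compound 3 `COc1ccc(-c2ccc3nnc([C@@H](C)c4ccc5ncccc5c4)n3n2)cc1C` gives 1770 nM, the lowest number of the three compounds measured so far. Compound 1 `C[C@@H](c1ccc2ncccc2c1)c1nnc2ccc(-c3cccc(C#N)c3)nn12` gives 32500 nM, and compound 2 `Nc1ccc2nnc(Cc3ccc4ncccc4c3)n2n1` gives 453000 nM. Compound 4 `C[C@@H](c1ccc2ncccc2c1)c1nnc2ccc(-c3ccccc3C#N)nn12` differs from compound 3 by 2-cyanophenyl in place of 4-methoxy-3-methylphenyl on an aromatic carbon, with 2-cyanophenyl in place of 4-methoxy-3-methylphenyl on an aromatic carbon. Within the data shown here, one measured step bears on this change: an 18-fold lower number from compound 1 to compound 3 (1.26 log units; beyond the scatter). That step is large and beyond the scatter. It put in the group that compound 4 loses, replacing 3-cyanophenyl, so a reversal of similar size is expected, although the two nitrile-bearing groups are not identical. The expected step is a 21-fold higher number from compound 3 to compound 4 (1.33 log units; beyond the scatter), a large one toward a higher number. For compound 4 the estimate is 38000 nM, with an expected range from 13000 nM to 110000 nM.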

Compound 4, solubility: 213000 nM
Beside the measured number, compound 4's estimate is 5.6-fold (0.75 log units) below it, outside the stated range (above it).
By their numbers in this assay, from the lowest: compound 3; then compound 1; then compound 4; then compound 2.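

At this aromatic carbon of the shared core, this assay shows a 120-fold higher number from compound 3 to compound 4 (2.08 log units; beyond the scatter) when 2-cyanophenyl replaces 4-methoxy-3-methylphenyl. The two nitrile-bearing groups do not read alike either: 2-cyanophenyl in place of 3-cyanophenyl gives a 6.6-fold higher number from compound 1 to compound 4 (0.82 log units; beyond the scatter), so the place of the nitrile on the phenyl ring matters here as well as its presence. Nothing available explains either step. The compounds shown leave open how a phenyl ring carrying a carboxylic acid, or a morpholine directly on this carbon, would read in this assay.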